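The source may report more compounds than this note shows. Statements on the series, on what has been measured and on what is new or still open speak of the compounds shown alone.

Compound 1 `CO[C@@H]1[C@H](N(C)c2ncc(-c3c[nH]c4ccccc34)s2)C[C@H]2O[C@]1(C)n1c3ccccc3c3c4c(c5c6cc(Cl)ccc6n2c5c31)C(=O)NC4` is tested in a functional assay on MV4-11 cells (Homo sapiens) for antiproliferative activity, read by CellTiter-Glo, with a stated time of 72 h (a higher number here means a weaker inhibitor, a lower number a stronger inhibitor), where compound 1 gives 560 nM. Two close relatives have been measured in the same way: compound 2 `CO[C@@H]1[C@H](N(C)c2ncc(-c3c[nH]c4ccc(F)cc34)s2)C[C@H]2O[C@]1(C)n1c3ccccc3c3c4c(c5c6cc(Cl)ccc6n2c5c31)C(=O)NC4` gives 320 nM and compound 3 `CO[C@@H]1[C@H](N(C)c2ncc(-c3c[nH]c4ccc(Br)cc34)s2)C[C@H]2O[C@]1(C)n1c3ccccc3c3c4c(c5c6cc(Cl)ccc6n2c5c31)C(=O)NC4` gives 430 nM. The steps of a 1.8-fold lower number from compound 1 to compound 2 (0.24 log units; within the scatter), a 1.3-fold lower number from compound 1 to compound 3 (0.11 log units; within the scatter) and a 1.3-fold higher number from compound 2 to compound 3 (0.13 log units; within the scatter) all stay within the scatter, so compound 1 is indistinguishable from both of its neighbours on these numbers. Compound 4 `CO[C@@H]1[C@H](N(C)c2ncc(-c3c[nH]c4ccccc34)s2)C[C@H]2O[C@]1(C)n1c3ccccc3c3c4c(c5c6cc(Br)ccc6n2c5c31)C(=O)NC4` differs from compound 1 by bromo in place of chloro on an aromatic carbon. For the measured compounds named here, no measured step touches that place; the three halogen changes that have been measured all fell within the scatter, so no step beyond the scatter is expected in this assay for compound 4. Compound 4 is therefore estimated at 520 nM (range 250 nM to 1100 nM), which means an expected step of a 1.1-fold lower number from compound 1 to compound 4 (0.03 log units; within the scatter).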

Compound 4, half-maximal inhibitory concentration: 360 nM
Compound 4: middle estimate off by 1.4-fold (0.16 log units), on the high side; the range from low to high includes it.
By their numbers in this assay, from the lowest: compounds 2, 4, 3 and 1 (each within the scatter of the next).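

In this assay, the chloro position on the shared core gets its first measured change, and bromo in place of chloro gives a 1.6-fold lower number from compound 1 to compound 4 (0.19 log units; within the scatter). This position therefore tolerates this swap of one halogen for another within the scatter, as the earlier halogen changes elsewhere on the molecule did. No available evidence bears on this result. Going by these compounds, whether an amine, a methoxy group or a nitrile at this position would also stay within the scatter remains open. So does the outcome of pairing this bromo with the fluoro of compound 2.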